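The source may report more compounds than this note shows. Statements on the series, on what has been measured and on what is new or still open speak of the compounds shown alone.

Compound 1, `CCCCN(CC)c1cc(C)nc2c1NC(=O)CN2c1ccc(Br)cc1Cl`, is the starting point. In an assay on HEK-293T cells for displacement of a labelled ligand from corticotropin-releasing factor receptor 1 (Homo sapiens), read by scintillation counting, with a stated time of 2 h (on this read-out lower numbers stand for stronger inhibition and higher numbers for weaker inhibition), compound 1 gives 2.7 nM. Compound 2, `CCCCN(CC)c1cc(C)nc2c1NC(=O)CN2c1ccc(Br)cc1C`, differs from it in a single place, a methyl group standing on an aromatic carbon where compound 1 carries chloro; in this assay compound 2 gives 4.4 nM. That one change produced a 1.6-fold higher number from compound 1 to compound 2 (0.21 log units; within the scatter), so on this read-out the two compounds cannot be told apart. Among the measured compounds shown here, of the two numbers known so far, compound 2 holds the higher one, with compound 1 nearest, though the gap between them is within the scatter and settles nothing. Compound 3, `CCCCN(CC)c1cc(C)nc2c1NC(=O)CN2c1ccc(Cl)cc1C`, is the next step: chloro in place of bromo on an aromatic carbon, which read one bond further out is 4-bromo-2-methylphenyl becoming 4-chloro-2-methylphenyl. For the measured compounds named here, no measured step shows one halogen traded for another on this ring; the only step known swapped a halogen for methyl and stayed within the scatter. With compound 3 the step of a 1.1-fold higher number from compound 2 to compound 3 (0.06 log units; within the scatter) is expected, not beyond the scatter. The estimate for compound 3 in this assay is 5 nM, within a range from 2 nM to 12 nM.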

Compound 3, inhibition constant: 5.4 nM
Compound 3: the middle estimate sits 1.1-fold (0.03 log units) below what was measured, and the stated range covers the measured number.
By their numbers in this assay, from the lowest: compounds 1, 2 and 3 (each within the scatter of the next).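

Putting chloro in place of bromo on the aromatic carbon para to a large group and meta to a methyl group gives a 1.2-fold higher number from compound 2 to compound 3 (0.09 log units; within the scatter), so in this assay these two halogens cannot be told apart at this position, something the earlier swap of chloro for methyl could not show. Read as one change on the ring attached to the core, 4-bromo-2-chlorophenyl becoming 4-chloro-2-methylphenyl gives a 2.0-fold higher number from compound 1 to compound 3 (0.30 log units; within the scatter), so even with both ring groups differing, the numbers stay within the scatter of each other. No measurement at hand bears on why these groups give such similar numbers.

The compounds shown leave open whether this position would give similar numbers with something other than a halogen, such as a methoxy group, an amine or a carboxylic acid, or with only hydrogen there. On these data alone, the butyl and ethyl groups on the amine nitrogen are the same in all three compounds, so the effect of a longer chain at that nitrogen also remains unknown.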